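Ester variation on the shared core

The source may report more compounds than this note shows. Statements on the series, on what has been measured and on what is new or still open speak of the compounds shown alone.

Measured so far:
compound 1 `CCCOC(=O)c1c(C)coc1-c1ccc2c(CC)cccc2c1OC`: in a functional assay on KB cells (Homo sapiens) for cytotoxicity, read by MTT assay, with a stated time of 72 h (on this read-out higher numbers stand for an effect only at larger amounts of compound and lower numbers for an effect already at smaller amounts), compound 1 gives only a limit, > 10 ug/mL.
compound 2 `CCc1cccc2c(OC)c(-c3occ(C)c3C(=S)OC)ccc12`: in this assay compound 2 gives 4.3 ug/mL.

Compound 1 stands at the limit of the assay, (the limit of > 10 ug/mL in this assay, at which 1 of the 2 values shown sits), and no number is known for it. Among the measured compounds shown here, the single measured step, an at least 2.3-fold lower number from compound 1 to compound 2 (0.36 log units; beyond the scatter), exchanges the propyl ester for a methyl thioester and brings the value inside the measurable range.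

Compound 3 `CCc1cccc2c(OC)c(-c3occ(C)c3C(=O)On3nnc4ccccc43)ccc12` differs from compound 1 by a group of 9 heavy atoms (6 carbon, 3 nitrogen; one five-membered aromatic ring with 3 hetero atoms, one six-membered aromatic ring of carbon only) in place of a group of 3 heavy atoms (3 carbon; no ring), on an oxygen next to a carbonyl group. For the measured compounds named here, this again alters the ester part of compound 1, so the step from compound 1 to compound 2 is the only one that bears on it, but the entering group here is larger and bicyclic, and no measured step covers a change of that kind. A step in the same direction, of modest size, is therefore expected, with wide uncertainty.

Compound 3 is estimated at 7 ug/mL, with a range from 2 ug/mL to 30 ug/mL. This estimate for compound 3 corresponds to an at least 1.4-fold lower number from compound 1 to compound 3 (0.15 log units; that floor lies within the scatter). A result reported only as a limit remains about as likely as a number.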

Compound 3, concentration for half-maximal effect: > 10 ug/mL
Compound 3 ended at the assay's limit (the forecaster's own chance of this, stated with the estimate: 45%); at least 1.4-fold (0.15 log units) between middle value and limit.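

In this assay, among the compounds shown here, compound 3 gives > 10 ug/mL as a limit and not a number, as compound 1 also does, so no step between compound 1 and compound 3 can be read. The compounds shown leave open whether exchanging propyl for the larger bicyclic group changes the read-out at all.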